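Methoxy for fluoro on the aryl ring of compound 3

This account rests on a few compounds, and the source may have more. Where it says the series, first, only, none or still open, it means among the compounds named here.

In a functional assay on Calu-3 cells (Homo sapiens) for cytotoxicity, read by WST assay, with a stated time of 72 h (a higher number here means a weaker inhibitor, a lower number a stronger inhibitor), compound 3 `Cn1c(-c2cc(-c3ccc(F)cc3)no2)cc2ccccc21` gives only a limit, > 100000 nM. Compound 1 `COc1ccc(-c2cc(-c3cc4ccccc4n3C)no2)cc1` likewise reaches only a limit, > 100000 nM. Compound 2 `COc1ccc(-c2cc(-c3c(Cl)c4ccccc4n3C)no2)cc1` gives a number, 60900 nM. Within the data shown here, the single measured step in the set, an at least 1.6-fold lower number from compound 1 to compound 2 (0.21 log units; that floor lies within the scatter), is the chloro in place of hydrogen on an aromatic carbon, and it concerns the core rather than the aryl ring. The weight of the shown values lies at the limit of > 100000 nM in this assay, at which 2 of the 3 values shown sit.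

Compound 4 `COc1ccc(-c2cc(-c3cc4ccccc4n3C)on2)cc1` is to be measured in this assay. It differs from compound 3 by methoxy in place of fluoro on an aromatic carbon. Among the measured compounds shown here, compound 1 also carries a methoxy on that ring, though on a core that is not the same as that of compound 4; no step between compound 1 and compound 4 is given, so its value only shows what a methoxy analogue can do in this assay. For the measured compounds named here, no measured step bears directly on a methoxy in place of fluoro, so no shift beyond the scatter is expected, and compound 3 itself supplies only a limit as a starting point.

Compound 4 is therefore expected to sit at the same limit, with an estimate of 150000 nM spanning 60000 nM to 400000 nM, the implied step being a step that the limit leaves unreadable from compound 3 to compound 4, most likely reported only as a limit.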

Compound 4, half-maximal inhibitory concentration: > 100000 nM
Compound 4 was reported as a limit; the forecaster's own chance of this, stated with the estimate: 80%; the middle value is on the limit's open side.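

Compound 3 stands only as a limit, > 100000 nM, in this assay. Among these compounds, compound 4 is likewise only a limit, > 100000 nM, so no step between compound 3 and compound 4 can be read. The compounds shown leave open whether methoxy in place of fluoro on the aromatic ring changes the number at all in this assay.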